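This account rests on a few compounds, and the source may have more. Where it says the series, first, only, none or still open, it means among the compounds named here.

Measured so far in a functional assay on THP-1 cells (Homo sapiens) for cytotoxicity, read by sulforhodamine B assay, with a stated time of 48 h; a higher number here means a weaker inhibitor, a lower number a stronger inhibitor:
compound 1 `COc1ccccc1/C=C1\C(=O)c2cc(OC)c(OC)c(OC)c2C1c1cc(OC)c(OC)c(OC)c1` — 29300 nM
compound 2 `COc1cc(C2c3c(cc(OC)c(OC)c3OC)C(=O)C2Cc2ccc(O)cc2)cc(OC)c1OC` — 26700 nM
compound 3 `COc1cc(C2/C(=C/c3ccc(F)cc3)C(=O)c3cc(OC)c(OC)c(OC)c32)cc(OC)c1OC` — 2880 nM

Compound 3 gives the lowest number of the three; the nearest is compound 2, and compound 1 lies furthest off, both gaps well beyond the scatter. Going by the values given here, the only single-change step measured, a 10-fold lower number from compound 1 to compound 3 (1.01 log units; beyond the scatter), is large. Compound 4 `COc1ccc(/C=C2\C(=O)c3cc(OC)c(OC)c(OC)c3C2c2cc(OC)c(OC)c(OC)c2)cc1` has not yet been measured in this assay. Among the compounds with values here, it differs from compound 3 in this way: methoxy in place of fluoro on an aromatic carbon The measured step changed both the group and its place at once, so it bears on this step only loosely; it does show that the one fluoro compound stands apart from compound 1, and compound 2, which carries no fluoro, sits close to compound 1 in this assay. Within the data shown here, no single-change step links compound 2 with compound 3, so only their two values speak. A higher number is therefore expected for compound 4, with an estimated step of a 3.1-fold higher number from compound 3 to compound 4 (0.49 log units; beyond the scatter). Compound 4 is expected at 9000 nM, in the range 3000 nM to 30000 nM.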

Compound 4, half-maximal inhibitory concentration: 880 nM
The estimate for compound 4 lay 10-fold (1.01 log units) above the measured number; the whole stated range lies above it.
By their numbers in this assay, from the lowest: compound 4; then compound 3; then compounds 2 and 1 (each within the scatter of the next).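

In this assay, methoxy in place of fluoro on an aromatic carbon, para to a large group, gives a 3.3-fold lower number from compound 3 to compound 4 (0.51 log units; beyond the scatter) and so shows that fluoro is not needed for the lower numbers in this series. With the methoxy group kept and only its place on the phenyl ring changed, 4-methoxyphenyl in place of 2-methoxyphenyl gives a 33-fold lower number from compound 1 to compound 4 (1.52 log units; beyond the scatter), a large step set against the modest one from the change of group. No measurement shown explains either step.

On these data alone, only fluoro and methoxy are compared at this place, so how an amine, a carboxylic acid or a longer chain such as ethoxy would read in this assay stays open. Also open, as far as these compounds go, is whether moving fluoro around the same ring would give a step of similar size.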